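This account rests on a few compounds, and the source may have more. Where it says the series, first, only, none or still open, it means among the compounds named here.

Measured compounds:

Compound 1, `COc1cc(-c2cc(/C=C/C(=O)c3ccc(N)cc3)[nH]n2)cc(OC)c1OC`, gives 98%.
Compound 2, `COc1ccc(-c2cc(/C=C/C(=O)c3ccc(N)cc3)[nH]n2)cc1OC`, gives 98%.
Compound 3, `COc1cc(C(=O)/C=C/c2cc(-c3cc(OC)c(OC)c(OC)c3)n[nH]2)cc(OC)c1OC`, gives 97%.

All three were tested in a functional assay on RPMI-8226 cells (Homo sapiens) for cytotoxicity, read by sulforhodamine B assay, with a stated time of 48 h, tested at 0.01 uM; on this read-out lower numbers stand for a stronger effect and higher numbers for a weaker effect at the one concentration tested. Compound 1 and compound 2 share a core and differ in one place: hydrogen in place of methoxy on an aromatic carbon. The step of no change at the digits printed from compound 1 to compound 2 (within the scatter) shows that this change left the read-out essentially where it was. Compound 3 carries a different core; how its core differs from that of compound 1 is not broken down here. In this assay compound 3 gives a number that lies within the scatter of both compound 1 and compound 2, so none of the three can be set apart from the others.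

Compound 4, `COc1ccc(-c2cc(/C=C/C(=O)c3cc(OC)c(OC)c(OC)c3)[nH]n2)cc1OC`, has not yet been measured. It differs from compound 3 in exactly the same way that compound 2 differs from compound 1: hydrogen in place of methoxy on an aromatic carbon. Since the same change on the core of compound 1 produced no change at the digits printed from compound 1 to compound 2 (within the scatter), the expectation is that the change on the core of compound 3 will likewise produce no step beyond the scatter, that is, an expected no change at the digits printed from compound 3 to compound 4 (within the scatter). Going by the values given here, this rests only on the one measured pair, compound 1 and compound 2, and on the very high read-outs of all three measured compounds, which leave little room for the number to rise.

On that basis compound 4 is estimated to give 97% in this assay, with a likely range from 88% to 103%.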

Compound 4, a percentage reported as activity, at one concentration (the size of the read-out at that concentration, not a potency): 97%
For compound 4 middle estimate and measured number coincide at the digits printed, within the range that was stated.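

In this assay, putting hydrogen in place of methoxy on an aromatic carbon of the core of compound 3 gave no change at the digits printed from compound 3 to compound 4 (within the scatter). The change therefore read the same on both cores shown, with the second step matching the first: the same change on two cores in this assay, no change at the digits printed (within the scatter) from compound 1 to compound 2 and no change at the digits printed (within the scatter) from compound 3 to compound 4, 0 percentage points apart, within the scatter of two such steps This shows only that the change left the read-out in place on these two cores at the one concentration tested, where all four compounds give numbers that stand for a weak effect, so it does not show that the change would be neutral on a compound with a stronger effect, at another concentration or on any further core.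

The compounds shown leave open whether a hydroxyl group, a chlorine atom or a longer alkoxy chain such as ethoxy on that aromatic carbon would move the read-out away from the values seen here. They also leave open how the same swap of methoxy for hydrogen would read on a core carrying a carboxylic acid where compound 1 carries its amine.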